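This account rests on a few compounds, and the source may have more. Where it says the series, first, only, none or still open, it means among the compounds named here.

Going by the values given here, in a functional assay on A20 cells (Mus musculus) for inhibition, with stated times of 1 h, 16 h and 24 h (on this read-out higher numbers stand for weaker inhibition and lower numbers for stronger inhibition), compound 3 (`N#CC1(NC(=O)[C@@H]2C[C@@H](S(=O)(=O)c3ccccc3)C[C@H]2C(=O)N2CCS(=O)(=O)CC2)CC1`) gives 816 nM, the highest of the three numbers so far. Compound 2 (`N#CC1(NC(=O)[C@@H]2C[C@@H](S(=O)(=O)c3ccccc3)C[C@H]2C(=O)N2CC3CCC(C2)O3)CC1`) gives 16 nM, and compound 1 (`C[C@@H]1CN(C(=O)[C@@H]2C[C@H](S(=O)(=O)c3ccccc3)C[C@H]2C(=O)NC2(C#N)CC2)C[C@H](C)O1`) gives 1 nM. Compound 4 (`N#CC1(NC(=O)[C@@H]2C[C@@H](S(=O)(=O)c3ccccc3)C[C@H]2C(=O)Nc2ccc(F)cc2)CC1`) is still unmeasured. Its change is (4-fluorophenyl)amino in place of 1,1-dioxothiomorpholin-4-yl on a carbonyl carbon.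

Two measured steps involve the group that leaves: an 820-fold higher number from compound 1 to compound 3 (2.91 log units; beyond the scatter) and a 51-fold higher number from compound 2 to compound 3 (1.71 log units; beyond the scatter). Both are large, and both end at the higher number of compound 3. The step of a 16-fold higher number from compound 1 to compound 2 (1.20 log units; beyond the scatter) is also large, so the two groups with lower numbers are themselves well apart. None of these steps brings an aromatic ring or an amide hydrogen to this carbonyl carbon, so they support a direction better than a size. A large move to a lower number is therefore expected in this assay, though probably not as far as compound 1. The expected change is a 14-fold lower number from compound 3 to compound 4 (1.13 log units; beyond the scatter). For compound 4 the estimated value is 60 nM, with an expected range from 10 nM to 350 nM.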

Compound 4, half-maximal inhibitory concentration: 391 nM
For compound 4 the middle estimate is 6.5-fold (0.81 log units) below the measured one, outside the stated range (above it).
By their numbers in this assay, from the lowest: compound 1; then compound 2; then compound 4; then compound 3.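

In this assay, putting (4-fluorophenyl)amino on this carbonyl carbon gives only a 2.1-fold lower number from compound 3 to compound 4 (0.32 log units; beyond the scatter), a modest step though beyond the scatter, so an aromatic ring and the amide hydrogen together do little here compared with the other changes at this position. The non-aromatic ring groups holding an oxygen keep a wide lead, with a 24-fold higher number from compound 2 to compound 4 (1.39 log units; beyond the scatter) and a 390-fold higher number from compound 1 to compound 4 (2.59 log units; beyond the scatter), so among these four compounds the lowest numbers belong to those two groups and no compound goes against this. No measurement available here accounts for this order.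

The compounds shown do not separate the fluorine from the phenyl ring, nor the two methyl groups from the ring of 2,6-dimethylmorpholin-4-yl. Plain phenylamino and unsubstituted morpholin-4-yl on this carbonyl carbon would speak to both points.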